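Series notes: methyl to allyl on the amide-type nitrogen

A few compounds are considered here, and "the series" means these few. Any claim that something is new, unique, unknown or untested is made for them only; others in the source may bear on it.

Compound 1 `NC(=S)N/N=C1/CCCc2cccnc21` and compound 2 `CNC(=S)N/N=C1/CCCc2cccnc21` share one core. In a toxicity assay on the whole organism (P388 cells, strain CDF1) for cytotoxicity, with Mus musculus as the target, with stated times of 6 days and 24 h, at a dose of 10 mg/kg (a higher number here means a weaker effect of the compound at the dose given, a lower number a stronger effect), compound 1 gives -21.5% and compound 2 gives -10.8%, so compound 2 stands highest of the two numbers. Among the measured compounds shown here, the single measured step, a number 10.7 percentage points higher from compound 1 to compound 2 (beyond the scatter), is methyl in place of hydrogen on an amide-type nitrogen. Compound 3 `C=CCNC(=S)N/N=C1/CCCc2cccnc21` differs from compound 2 by vinyl in place of hydrogen on a saturated chain carbon bound to an amide-type nitrogen. For the measured compounds named here, no measured step touches a saturated chain carbon bound to that nitrogen, so this change has no direct precedent; the only prior step was modest. For compound 3 the expected step in this assay is a number 4.8 percentage points higher from compound 2 to compound 3 (within the scatter), within the scatter. The estimate for compound 3 is -6%, range -26% to 14%.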

Compound 3, a percentage reported as activity, at one dose (the size of the read-out at that dose, not a potency): -6.1%
Beside the measured number, compound 3's estimate is 0.1 percentage points above it; the range from low to high includes it.
By their numbers in this assay, from the lowest: compound 1; then compounds 2 and 3 (each within the scatter of the next).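

In this assay, the change from methyl to allyl on the amide-type nitrogen gives a number 4.7 percentage points higher from compound 2 to compound 3 (within the scatter), so adding vinyl at this saturated chain carbon does not separate the two compounds beyond the scatter. Allyl in place of hydrogen on the amide-type nitrogen gives a number 15.4 percentage points higher from compound 1 to compound 3 (beyond the scatter), so the step beyond the scatter seen with methyl is also seen with allyl. No data are available to explain either step.

Going by these compounds, whether a longer saturated chain, a phenyl ring or a terminal amine on this nitrogen would stay level with compound 2 and compound 3 remains open.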